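Lipophilicity notes on the methylsulfonyl anilide series

The compounds below may be only part of what the source reports. "The series", "measured", "known", "first", "only" and "open" are said of these compounds alone.

Measured so far in a physicochemical assay for lipophilicity, using the shake flask method, in phosphate buffer, measured as octanol-water partition, with a stated time of 5 h, at pH 7.4; on this read-out higher numbers stand for higher lipophilicity and lower numbers for lower lipophilicity:
compound 1, `Cc1cnc(Nc2cc(N3CCNCC3)cc(S(C)(=O)=O)c2)nc1Nc1cccc(CO)c1`, gives 1.09
compound 2, `CN1CCN(c2cc(Nc3ncc(Cl)c(Nc4cccc(CO)c4)n3)cc(S(C)(=O)=O)c2)CC1`, gives 2.16
compound 3, `Cc1cnc(Nc2cc(N3CCN(C)CC3)cc(S(C)(=O)=O)c2)nc1Nc1cccc(CO)c1`, gives 1.74

Compound 3 stands second highest of the three numbers: nearest to compound 2, furthest from compound 1, both gaps beyond the scatter. The two steps that reach compound 3 are a number 0.65 log units higher from compound 1 to compound 3 (beyond the scatter) and a number 0.42 log units lower from compound 2 to compound 3 (beyond the scatter).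

Compound 4, `Cc1cnc(Nc2cc(N3C[C@@H]4C[C@H]3CN4C)cc(S(C)(=O)=O)c2)nc1Nc1cccc(CO)c1`, is the next candidate in this assay. Relative to compound 3 the change is a group of 8 heavy atoms (6 carbon, 2 nitrogen; 2 five-membered non-aromatic rings with 1 hetero atom each) in place of a group of 7 heavy atoms (5 carbon, 2 nitrogen; one six-membered non-aromatic ring with 2 hetero atoms), on an aromatic carbon. Within the data shown here, no measured step covers this exchange of one ring system for another. Among the measured compounds shown here, the only step touching the same part of the molecule is a number 0.65 log units higher from compound 1 to compound 3 (beyond the scatter), which attached a methyl to the amine nitrogen in the ring; here the entering group carries one more heavy atom than the leaving group and keeps the same count of hydrogen-bond donors and acceptors. A modest upward step is therefore expected, a number 0.31 log units higher from compound 3 to compound 4 (beyond the scatter), smaller than the methyl step because that step, a number 0.65 log units higher from compound 1 to compound 3 (beyond the scatter), added a whole group rather than one atom.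

Compound 4 is estimated at 2.05, with a range from 1.6 to 2.5.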

Compound 4, distribution coefficient: 0.82
For compound 4 the middle estimate is 1.23 log units above the measured one, outside the stated range (below it).
By their numbers in this assay, from the lowest: compounds 4 and 1 (each within the scatter of the next); then compound 3; then compound 2.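

In this assay, the group on this aromatic carbon, meta to a methylsulfonyl group, can also pull the number down: replacing 4-methylpiperazin-1-yl with the group of two five-membered non-aromatic rings gives a number 0.92 log units lower from compound 3 to compound 4 (beyond the scatter), although the entering group has one more heavy atom and the same counts of hydrogen-bond donors and acceptors. Heavy-atom count and those donor and acceptor counts therefore do not track the read-out across this exchange, and the comparison with the smaller ring group of compound 1 gives a number 0.27 log units lower from compound 1 to compound 4 (within the scatter). Nothing available explains the size or direction of this change.

Still open, going by these compounds, is how the two-ring group would read without its methyl, or with the opposite configuration at its two stereocentres. A morpholine or an open-chain dimethylamino group at this carbon would test whether the downward step is specific to this two-ring group.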